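The source may hold more compounds than are shown below. What is called first, only, known or untested is meant among the compounds shown, and "the series" means these compounds.

Measured so far in an assay on HEK293 cells for activation of Kir3.1/Kir3.2 (Homo sapiens), read by thallium flux; a lower number here means that less compound is needed, a higher number that more compound is needed for the effect:
compound 1 `Cc1cc(NC(=O)Cn2nnc(-c3ccccc3)n2)n(C2CC2)n1`: > 5000 nM
compound 2 `Cc1nc(-c2ccccc2)c(NC(=O)Cn2nnc(-c3ccccc3)n2)s1`: "not active" (no number reported)
compound 3 `Cc1cc(NC(=O)Cn2nnc(-c3ccc(F)cc3)n2)n(C2CCCCC2)n1`: 180 nM

Within the data shown here, compound 3 carries the only number in this assay. Compound 1 gives > 5000 nM, which is a limit of the assay and not a number (the limit of > 5000 nM in this assay, at which 1 of the 3 values shown sits). Compound 2 is reported as "not active" (no number reported) with no number. Neither entry supports a comparison of size with compound 3.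

Compound 4 `Cc1cc(NC(=O)Cn2nnc(-c3ccc(C(F)(F)F)cc3)n2)n(C2CCCCC2)n1` differs from compound 3 in one place: trifluoromethyl in place of fluoro on an aromatic carbon. Among the measured compounds shown here, no measured pair shows this change, so the step from compound 3 to compound 4 in this assay is expected to be small, within the scatter or little beyond it, in either direction. Compound 4 is expected near 220 nM, between 70 nM and 700 nM, an expected step of a 1.2-fold higher number from compound 3 to compound 4 (0.09 log units; within the scatter).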

Compound 4, half-maximal effective concentration: 241 nM
Compound 4: middle estimate off by 1.1-fold (0.04 log units), on the low side; the measured number falls inside the stated range.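

In this assay, among these compounds, trifluoromethyl in place of fluoro on an aromatic carbon, para to a large group, gives a 1.3-fold higher number from compound 3 to compound 4 (0.13 log units; within the scatter), the first step that can be read at this position. This position therefore takes 4 heavy atoms in place of 1 with no step beyond the scatter. No measured property shown bears on this step.

On these data alone, whether an amine, a carboxylic acid or a longer chain at this position would stay within the scatter remains open. As far as these compounds go, compound 1 and compound 3 differ in more than one place, so the contribution of each difference also remains open.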